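A few compounds are considered here, and "the series" means these few. Any claim that something is new, unique, unknown or untested is made for them only; others in the source may bear on it.

Measured in a functional assay on K562 cells (Homo sapiens) for cytotoxicity, read by ELISA, with a stated time of 4 days; a higher number here means a weaker inhibitor, a lower number a stronger inhibitor:
- compound 1 `Clc1ccc(-c2cc(-c3ccoc3)cc(-c3ccco3)n2)s1`: 16200 nM
- compound 2 `Clc1cccc(-c2cc(-c3ccoc3)cc(-c3ccc(Cl)s3)n2)c1`: 22100 nM
- compound 3 `Cc1ccsc1-c1cc(-c2ccc(Cl)o2)cc(-c2cccc(Cl)c2)n1`: 13400 nM

Compound 3 stands at 13400 nM, within the scatter of both compound 1 and compound 2, so these three cannot be ranked. Compound 4 `Cc1ccsc1-c1cc(-c2ccc(Cl)o2)cc(-c2cccnc2)n1`, not yet measured, carries pyridin-3-yl in place of 3-chlorophenyl on an aromatic carbon. Among the compounds with values here, only one measured step involves the departing group: a 1.4-fold higher number from compound 1 to compound 2 (0.13 log units; within the scatter), where 3-chlorophenyl replaced furan-2-yl and the change stayed within the scatter. Within the data shown here, no measured compound here carries pyridin-3-yl, so this is weak guidance, and no step beyond the scatter is expected. The estimated move is a 1.1-fold higher number from compound 3 to compound 4 (0.05 log units; within the scatter). For compound 4 the expected value is 15000 nM, with an estimated range of 6000 nM to 38000 nM.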

Compound 4, half-maximal inhibitory concentration: 12300 nM
The estimate for compound 4 lay 1.2-fold (0.09 log units) above the measured number; the measured number falls inside the stated range.
By their numbers in this assay, from the lowest: compounds 4, 3, 1 and 2 (each within the scatter of the next).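

In this assay, putting pyridin-3-yl in place of 3-chlorophenyl gives a 1.1-fold lower number from compound 3 to compound 4 (0.04 log units; within the scatter), so at this position, next to the ring nitrogen, a carbon-only ring and a ring carrying one nitrogen cannot be told apart. The earlier step showed 3-chlorophenyl only against furan-2-yl, and this one adds a six-membered partner with a hydrogen-bond acceptor. Nothing measured here bears on the reason for this result.

On these data alone, whether any group at this position can move the number beyond the scatter stays open. A non-aromatic group, such as an amine or a carboxylic acid, would test that.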